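This account rests on a few compounds, and the source may have more. Where it says the series, first, only, none or still open, it means among the compounds named here.

Measured so far:
compound 1 `CC(C)(C)c1cc(CNC(=O)Nc2cccc3[nH]ncc23)n(-c2cccc(C(F)(F)F)c2)n1` gives 0.3 nM
compound 2 `CC(C)(C)c1cc(CNC(=O)Nc2cccc3[nH]ncc23)n(-c2ccc(C(F)(F)F)cc2)n1` gives 19.6 nM
compound 3 `COc1ccc(-n2nc(C(C)(C)C)cc2CNC(=O)Nc2cccc3[nH]ncc23)cc1` gives 62.9 nM

In an assay on CHO-K1 cells for antagonist activity at transient receptor potential cation channel subfamily V member 1 (Homo sapiens), read by FLIPR and calcium flux, with a stated time of 6 min (a higher number here means a weaker inhibitor, a lower number a stronger inhibitor), compound 3 stands at the highest of the three numbers: its nearest neighbour is compound 2, as the step of a 3.2-fold higher number from compound 2 to compound 3 (0.51 log units; beyond the scatter) shows, and its furthest is compound 1, as the step of a 210-fold higher number from compound 1 to compound 3 (2.32 log units; beyond the scatter) shows. Compound 4 `CC(C)(C)c1cc(CNC(=O)Nc2cccc3[nH]ncc23)n(-c2ccc(F)c(Cl)c2)n1` differs from compound 3 in one place: 3-chloro-4-fluorophenyl in place of 4-methoxyphenyl on an aromatic nitrogen. For the measured compounds named here, two measured steps bear on this change. The step of a 65-fold higher number from compound 1 to compound 2 (1.82 log units; beyond the scatter) shows how strongly the pattern of substitution on this phenyl ring moves the number, and the step of a 3.2-fold higher number from compound 2 to compound 3 (0.51 log units; beyond the scatter) shows that exchanging the trifluoromethyl for a methoxy at the same position raised it modestly. Compound 4 carries halogens at two positions of this ring, one of them matching the position that compound 1 occupies. A step downward in this assay, beyond the scatter, is therefore expected for compound 4, of about a 16-fold lower number from compound 3 to compound 4 (1.20 log units; beyond the scatter). Compound 4 is estimated at 4 nM, with a range from 0.6 nM to 25 nM.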

Compound 4, inhibition constant: 0.5 nM
Beside the measured number, compound 4's estimate is 8.0-fold (0.90 log units) above it; the measured number lies below the stated range.
By their numbers in this assay, from the lowest: compounds 1 and 4 (each within the scatter of the next); then compound 2; then compound 3.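

In this assay, the 3-chloro-4-fluorophenyl group separates sharply from both rings substituted only at the 4-position, with a 130-fold lower number from compound 3 to compound 4 (2.10 log units; beyond the scatter) and a 39-fold lower number from compound 2 to compound 4 (1.59 log units; beyond the scatter), whereas a 1.7-fold higher number from compound 1 to compound 4 (0.22 log units; within the scatter) leaves it level with the 3-(trifluoromethyl)phenyl group. A group at the 4-position of this ring therefore does not by itself go with a high number, since compound 4 carries fluorine there, and the low number is shared by a ring bearing chlorine and a ring bearing trifluoromethyl at the 3-position. Nothing measured here explains why this ring position responds so strongly.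

The compounds shown leave open how much each halogen contributes, as 3-chlorophenyl and 4-fluorophenyl rings are not among them. They also leave open whether an amine or a carboxylic acid on this ring would fit the same pattern.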